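One Added Methyl on Compound 2

This account rests on a few compounds, and the source may have more. Where it says the series, first, only, none or still open, it means among the compounds named here.

compound 1 `NC(=O)[C@@H]1CC[C@H](c2ccc(OCc3ccc(F)cc3)cc2)N1` gives 1.8 mL.min-1.g-1
compound 2 `NC(=O)[C@@H]1CC[C@H](c2ccc(OCc3ccccc3)cc2)N1` gives 0.5 mL.min-1.g-1
compound 3 `N#Cc1ccc(COc2ccc([C@H]3CC[C@@H](C(N)=O)N3)cc2)cc1` gives 0.6 mL.min-1.g-1

These numbers come from an ADME assay on microsomes from liver (Rattus norvegicus) for metabolic stability; a higher number here means faster removal of the compound, a lower number slower removal. Compound 2 sits at the low end of the set, level with its closest neighbour, as the step of a 1.2-fold higher number from compound 2 to compound 3 (0.08 log units; within the scatter) shows. The fluoro compound stands apart, with the steps of a 3.6-fold lower number from compound 1 to compound 2 (0.56 log units; beyond the scatter) and a 3.0-fold lower number from compound 1 to compound 3 (0.48 log units; beyond the scatter).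

Compound 4 `C[C@@H](Oc1ccc([C@H]2CC[C@@H](C(N)=O)N2)cc1)c1ccccc1` has methyl in place of hydrogen on a saturated chain carbon bound to an aromatic carbon and an oxygen on an aromatic ring.

For the measured compounds named here, no measured step touches that carbon. All three swap groups on an aromatic carbon, so they bear on this change only indirectly, as a guide to how far one small swap can move the number. They give no direction, so only a small step is expected here, perhaps slightly upward. The expected size is a 1.6-fold higher number from compound 2 to compound 4 (0.20 log units; within the scatter). The value of compound 4 is estimated at 0.8 mL.min-1.g-1 within an expected range from 0.3 mL.min-1.g-1 to 2.2 mL.min-1.g-1.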

Compound 4, intrinsic clearance in microsomes: 0.9 mL.min-1.g-1
Estimate against measurement, compound 4: 1.1-fold (0.05 log units) below; measured number inside the range.
By their numbers in this assay, from the lowest: compounds 2, 3, 4 and 1 (each within the scatter of the next, the first and the last beyond it).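

For the compounds shown here, this result gives the first reading at the saturated chain carbon bound to an aromatic carbon and an oxygen on an aromatic ring, since every earlier step swapped groups on an aromatic carbon. In this assay, methyl in place of hydrogen at this carbon gives a 1.8-fold higher number from compound 2 to compound 4 (0.26 log units; within the scatter), so adding this one carbon makes no change that can be told apart from the usual scatter. Nothing available explains this outcome or links it to any property of the methyl group.

The compounds shown leave open whether a longer chain such as ethyl, or a hydroxyl group, would behave the same way on this carbon. They also leave open how the methyl would act when combined with the fluoro group of compound 1.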